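Selenium-linked bis-amidines: cytotoxicity on prostate carcinoma cells

The source may report more compounds than this note shows. Statements on the series, on what has been measured and on what is new or still open speak of the compounds shown alone.

Measured compounds:
compound 1 `CS/C(=N\C(=O)c1ccno1)NC(=O)c1ccno1`, > 100000 nM
compound 2 `O=C(/N=C(/NC(=O)c1cc(-c2ccccc2)nc2ccccc12)[Se]Cc1ccccc1)c1cc(-c2ccccc2)nc2ccccc12`, 97100 nM

The series was run in a functional assay on PC-3 cells (Homo sapiens) for cytotoxicity, read by MTT assay, with a stated time of 72 h; on this read-out lower numbers stand for stronger inhibition of growth and higher numbers for weaker inhibition of growth. Compound 1 returns only a limit of the assay, > 100000 nM. Within the data shown here, compound 2 is the one compound with a numeric read-out, giving 97100 nM; the other value in the set sits at the limit of > 100000 nM in this assay, at which 1 of the 2 values shown sits, so compound 2 stands as the sole measured number and nothing in the set is ordered against it.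

Compound 3 `C[Se]/C(=N\C(=O)c1cc(-c2ccccc2)nc2ccccc12)NC(=O)c1cc(-c2ccccc2)nc2ccccc12` is still to be measured. It differs from compound 2 in one place: hydrogen in place of phenyl on a saturated chain carbon bound to a selenium atom, the same difference read one bond further out being benzyl to methyl. Among the measured compounds shown here, no step between two measured compounds exists for this kind of change, so no measured size can be drawn on. The expectation is a step within the scatter, with no direction beyond it, as a 1.0-fold higher number from compound 2 to compound 3 (0.01 log units; within the scatter). Compound 3 is accordingly estimated at 100000 nM, with a range from 40000 nM to 250000 nM, and a fair chance that this assay reports only a limit, as it does for compound 1.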

Compound 3, concentration for total growth inhibition: 40200 nM
The estimate for compound 3 lay 2.5-fold (0.40 log units) above the measured number; measured number inside the range.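

In this assay, the group on the selenium atom now proves able to shift the read-out: hydrogen in place of phenyl on a saturated chain carbon bound to a selenium atom, which reads as benzyl to methyl, gives a 2.4-fold lower number from compound 2 to compound 3 (0.38 log units; beyond the scatter). The step is modest but beyond the scatter, and its direction shows that the phenyl of the benzyl group is not required for growth inhibition in this pair, with the methyl compound giving the stronger inhibition. This is the first comparison in the series between two numeric values, and compound 1 stays outside it, with > 100000 nM being a limit of the assay and not a number: the limit of > 100000 nM in this assay, at which 1 of the 3 values shown sits.

The compounds shown leave open whether the number keeps moving along a run of groups on the selenium atom, such as an ethyl group, a longer chain or a chain ending in a carboxylic acid, or whether methyl and benzyl are simply two isolated points. Among these compounds, the part played by selenium itself also stays unresolved, as compound 1 differs from compound 3 in more than one place and no pair here exchanges that atom alone.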